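The source may report more compounds than this note shows. Statements on the series, on what has been measured and on what is new or still open speak of the compounds shown alone.

Measured so far in an assay on isolated protein for inhibition of protein kinase C theta type (Homo sapiens), read by TR-FRET, with a stated time of 2 h; a higher number here means a weaker inhibitor, a lower number a stronger inhibitor: compound 1 `N#Cc1cnc(NCc2cnccc2C(F)(F)F)cc1N[C@H]1C[C@H](O)C1` gives 900 nM; compound 2 `N#Cc1cnc(NCc2cnccc2C(F)(F)F)cc1NC[C@H]1CC[C@@H](O)CC1` gives 58 nM; compound 3 `CC1(C)C[C@@H](Nc2cc(NCc3cnccc3C(F)(F)F)ncc2C#N)CC[C@H]1O` gives 120 nM.

Compound 3 thus stands second highest of the three numbers. Compound 4 `CC1(C)[C@H](Nc2cc(NCc3cnccc3C(F)(F)F)ncc2C#N)C[C@H]1C(N)=O` differs from it by 3-carbamoyl-2,2-dimethylcyclobutyl in place of 4-hydroxy-3,3-dimethylcyclohexyl on a nitrogen on an aromatic ring. Going by the values given here, no measured step swaps a hydroxyl for a carbamoyl, so the closest guidance comes from the ring change: a 16-fold lower number from compound 1 to compound 2 (1.19 log units; beyond the scatter) and a 7.5-fold lower number from compound 1 to compound 3 (0.88 log units; beyond the scatter) both show a four-membered ring carrier giving a higher number than the six-membered ones, while a 2.1-fold higher number from compound 2 to compound 3 (0.32 log units; beyond the scatter) shows the dimethyl variant sitting modestly higher. Returning to a four-membered ring is therefore expected to raise the number for compound 4, to an estimated 400 nM (range 100 nM to 1600 nM), a step of a 3.3-fold higher number from compound 3 to compound 4 (0.52 log units; beyond the scatter).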

Compound 4, half-maximal inhibitory concentration: 140 nM
Compound 4: middle estimate off by 2.9-fold (0.46 log units), on the high side; measured number inside the range.
By their numbers in this assay, from the lowest: compound 2; then compounds 3 and 4 (each within the scatter of the next); then compound 1.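

In this assay, a four-membered ring on this nitrogen need not give a high number: 3-carbamoyl-2,2-dimethylcyclobutyl in place of 4-hydroxy-3,3-dimethylcyclohexyl gives a 1.2-fold higher number from compound 3 to compound 4 (0.07 log units; within the scatter). The same group gives a 2.4-fold higher number from compound 2 to compound 4 (0.38 log units; beyond the scatter) and a 6.4-fold lower number from compound 1 to compound 4 (0.81 log units; beyond the scatter), so ring size alone does not set the number, since compound 1 and compound 4 both carry a four-membered ring. No measurement here explains this. Still open, as far as these compounds go, is whether the carbamoyl or the two methyl groups account for the difference from compound 1, and how a carboxylic acid or an amine on the same ring would read.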